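The source may report more compounds than this note shows. Statements on the series, on what has been measured and on what is new or still open speak of the compounds shown alone.

In a functional assay on KB cells (Homo sapiens) for antiproliferative activity, read by sulforhodamine B assay, with a stated time of 3 days (on this read-out higher numbers stand for an effect only at larger amounts of compound and lower numbers for an effect already at smaller amounts), compound 2 `CCC1=C(O)c2c(oc(-c3ccc(C)c(Cl)c3)cc2=O)C(CC)(CC)C1=O` gives 39 uM and compound 3 `CCC1=C(O)c2c(oc(-c3cc(C)c(OC)cc3C)cc2=O)C(CC)(CC)C1=O` gives 36.6 uM, two numbers within the usual scatter of each other. Compound 1 `CCC1=C(O)c2c(oc(-c3ccc(CBr)cc3)cc2=O)C(CC)(CC)C1=O` reaches only a limit, > 46.5 uM. Compound 4 `CCC1=C(O)c2c(oc(-c3cc(C)ccc3C)cc2=O)C(CC)(CC)C1=O` carries hydrogen in place of the methoxy of compound 3 on an aromatic carbon, para to a large group (hydrogen in place of methoxy on an aromatic carbon). For the measured compounds named here, no measured step removes a methoxy. Going by the values given here, the one measured step, an at least 1.1-fold lower number from compound 1 to compound 2 (0.07 log units; that floor lies within the scatter), concerns other groups, and it offers only a weak guide. With so little to suggest a shift, no step beyond the scatter is expected. The expected change is a 1.0-fold higher number from compound 3 to compound 4 (0.02 log units; within the scatter). For compound 4 the estimate is 38 uM, with an expected range from 20 uM to 55 uM.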

Compound 4, concentration for half-maximal effect: 14.5 uM
For compound 4 the middle estimate is 2.6-fold (0.42 log units) above the measured one; the measured number lies below the stated range.
By their numbers in this assay, from the lowest: compound 4; then compounds 3 and 2 (each within the scatter of the next). At a limit, above all of these: compound 1.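

In this assay, hydrogen in place of methoxy on this aromatic carbon, para to a large group, gives a 2.5-fold lower number from compound 3 to compound 4 (0.40 log units; beyond the scatter), so this place on the ring does respond and the methoxy is not needed for the effect. With its 2,5-dimethylphenyl group, compound 4 also stands apart from the other two, with a 2.7-fold lower number from compound 2 to compound 4 (0.43 log units; beyond the scatter) and an at least 3.2-fold lower number from compound 1 to compound 4 (0.50 log units; beyond the scatter). The value of compound 1 is a limit and not a number, so that last step is only a floor: the limit of > 46.5 uM in this assay, at which 1 of the 4 values shown sits.

The compounds shown leave open what a hydroxyl, a fluorine or an amine would do on this same carbon. They also leave open whether either methyl group of compound 4 matters.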